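The source may hold more compounds than are shown below. What is called first, only, known or untested is meant among the compounds shown, and "the series" means these compounds.

Measured compounds:
- compound 1, `Nc1cc(N)c2nc(-c3ccccc3)c(Oc3ccc(Cl)c(Cl)c3)nc2c1`: 28200 nM
- compound 2, `CCOC(=O)[C@H](CCC(=O)O)NC(=O)c1ccc(Oc2nc3cc(N)cc(N)c3nc2-c2ccccc2)cc1`: 38000 nM
- compound 3, `COc1ccc(CNc2nc3cc(N)cc(N)c3nc2-c2ccccc2)cc1`: 14800 nM

These three compounds share one core and were all tested in a functional assay on OVCAR-8 cells (Homo sapiens) for inhibition, read by sulforhodamine B assay, with a stated time of 48 h; a lower number here means a stronger inhibitor of growth, a higher number a weaker inhibitor of growth. In this assay compound 1 gives 28200 nM. Compound 2 gives 38000 nM, and compound 3 gives 14800 nM. All three numbers sit close together: each of them lies within the usual scatter of the others, so compound 1 cannot be set apart from compound 2 or compound 3 on these values. None of the three is a strong inhibitor of growth.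

The next compound to consider is compound 4, `COc1ccc(Sc2nc3cc(N)cc(N)c3nc2-c2ccccc2)cc1`. It is built from compound 1 by one change: (4-methoxyphenyl)sulfanyl in place of 3,4-dichlorophenoxy on an aromatic carbon. The group that leaves and the group that enters are of the same size, each hanging from the same aromatic carbon of the core, next to the ring nitrogen and ortho to the phenyl group. Within the data shown here, no step between two measured compounds isolates this exchange, so nothing among the measured values tells how large its effect will be. Given that all three measured compounds stay within one narrow band, the most reasonable expectation is a step from compound 1 to compound 4 of a 1.4-fold lower number from compound 1 to compound 4 (0.15 log units; within the scatter) in this assay, that is, no change beyond the scatter, with a slight lean toward a lower number. Compound 4 is therefore estimated at 20000 nM in this assay, with a likely range from 7000 nM to 60000 nM.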

Compound 4, concentration for 50% growth inhibition: < 100000 nM
Compound 4 gave a limit, no number; the forecaster's own chance of this, stated with the estimate: 10%; the middle value lies beyond the limit too.
By their numbers in this assay, from the lowest: compounds 3, 1 and 2 (each within the scatter of the next, the first and the last beyond it).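

In this assay compound 4 gives < 100000 nM, which is a limit of the assay and not a number. No size can be read for the change from compound 1 to compound 4. The compounds shown leave open whether (4-methoxyphenyl)sulfanyl in place of 3,4-dichlorophenoxy alters growth inhibition at all, and in which direction.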